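Fluoro for chloro on the phenylamino group of compound 2

The compounds below may be only part of what the source reports. "The series", "measured", "known", "first", "only" and "open" are said of these compounds alone.

Compound 1 `C=CC(=O)Nc1cccc(NC(=O)CSc2nc(Nc3ccccc3Cl)c3ccccc3n2)c1`: 12700 nM
Compound 2 `C=CC(=O)Nc1cccc(NC(=O)CSc2nc(Nc3ccc(Cl)c(Cl)c3)c3ccccc3n2)c1`: 17700 nM

In a functional assay on MDA-MB-231 cells (Homo sapiens) for inhibition, read by MTT assay, with a stated time of 72 h (on this read-out lower numbers stand for stronger inhibition and higher numbers for weaker inhibition), compound 2 gives 17700 nM, the higher of the two numbers shown, though the step of a 1.4-fold higher number from compound 1 to compound 2 (0.14 log units; within the scatter) lies within the scatter. Compound 3 `C=CC(=O)Nc1cccc(NC(=O)CSc2nc(Nc3ccc(F)c(Cl)c3)c3ccccc3n2)c1` differs from compound 2 by fluoro in place of chloro on an aromatic carbon. Going by the values given here, only one step has been measured, and it exchanged one chloro pattern for another rather than a chloro for a fluoro; its size, a 1.4-fold higher number from compound 1 to compound 2 (0.14 log units; within the scatter), was within the scatter. No step beyond the scatter is therefore expected, a 1.0-fold lower number from compound 2 to compound 3 (0.02 log units; within the scatter). Compound 3 is estimated at 17000 nM, with a range from 8500 nM to 34000 nM.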

Compound 3, half-maximal inhibitory concentration: 10600 nM
Estimate against measurement, compound 3: 1.6-fold (0.21 log units) above; low and high end bracket the measured number.
By their numbers in this assay, from the lowest: compounds 3, 1 and 2 (each within the scatter of the next).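

Placing fluoro instead of chloro on this aromatic carbon gives a 1.7-fold lower number from compound 2 to compound 3 (0.22 log units; within the scatter), so this first direct exchange of one halogen for the other does not separate the two compounds. The 3-chloro-4-fluorophenyl group, set against 2-chlorophenyl, gives a 1.2-fold lower number from compound 1 to compound 3 (0.08 log units; within the scatter), so all three halogen patterns on the phenylamino group remain within the scatter of one another.

On these data alone, whether an amine or a methoxy group on this aromatic carbon would shift the number beyond the scatter stays open. Nothing available offers a reason for these small steps.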